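Fluorine on the carbamate chain of compound 3

The compounds below may be only part of what the source reports. "The series", "measured", "known", "first", "only" and "open" are said of these compounds alone.

Compound 3 `CC(C)OC(=O)N1CCC(O[C@H]2CC[C@H](Oc3cnc(S(C)(=O)=O)cn3)CC2)CC1` is the high point of the three measured compounds in a functional assay on isolated protein for agonist activity at Glucose-dependent insulinotropic receptor (Homo sapiens), read by HTRF and cAMP accumulation (a lower number here means a smaller maximal response, a higher number a larger maximal response), where compound 3 reaches 110%. Compound 1 `CC(C)OC(=O)N1CCC(O[C@H]2CC[C@H](Oc3ccc(S(C)(=O)=O)nc3)CC2)CC1` sits nearest, giving 101% in this assay, and the step of a number 9 percentage points higher from compound 1 to compound 3 (within the scatter) lies within the scatter. Among the compounds with values here, compound 2 `CC(C)(C)OC(=O)N1CCC(O[C@H]2CC[C@H](Oc3ccc(S(C)(=O)=O)nn3)CC2)CC1` is furthest, with 97% in this assay, a gap beyond the scatter, though compound 2 differs from compound 3 in two places and no single step is computed for that pair.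

Compound 4 `C[C@H](CF)OC(=O)N1CCC(O[C@H]2CC[C@H](Oc3cnc(S(C)(=O)=O)cn3)CC2)CC1` is the next compound to be measured. Against compound 3, the change is fluoro in place of hydrogen on a saturated chain carbon, two bonds along the chain from an oxygen next to a carbonyl group, which cut one bond further out reads isopropyl to 1-(fluoromethyl)ethyl.

Within the data shown here, no measured step touches this position: the only computed step, from compound 1 to compound 3, moves the aromatic ring on the oxygen on a saturated carbon and stays within the scatter, and compound 2 versus compound 3 mixes two changes. The maximal response across all three compounds is near full, so the expected step of a number 5 percentage points lower from compound 3 to compound 4 (within the scatter) is none beyond the scatter. Compound 4 is therefore estimated to give about 105% in this assay, between 90% and 120%.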

Compound 4, largest response reached (Emax), in percent of the reference or control that the assay uses: 108%
Compound 4: middle estimate off by 3 percentage points, on the low side; measured number inside the range.
By their numbers in this assay, from the lowest: compounds 2, 1, 4 and 3 (each within the scatter of the next, the first and the last beyond it).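

Within the data shown here, the step of a number 2 percentage points lower from compound 3 to compound 4 (within the scatter) is the first measured change on the carbamate chain itself, since the earlier step moved only the aromatic ring on the oxygen on a saturated carbon. It shows that, in this assay, replacing isopropyl with 1-(fluoromethyl)ethyl leaves the maximal response indistinguishable from that of compound 3, so this position accepts a fluoro in place of hydrogen without a readable difference on this read-out. No supporting measurement is available that could explain this result or link it to any property of the fluoro group.

What the compounds shown leave open is whether this position would accept more than this one substitution, such as difluoromethyl or trifluoromethyl in place of the fluoromethyl, a hydroxyl or an amine on the same carbon, or a longer chain such as a butyl carbamate. They also leave open whether the same fluoro change would read the same way with the 6-(methylsulfonyl)pyridin-3-yl group of compound 1 in place of the 5-(methylsulfonyl)pyrazin-2-yl group.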